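The source may report more compounds than this note shows. Statements on the series, on what has been measured and on what is new or still open speak of the compounds shown alone.

Compound 1 `O=C(CCc1cccc2c1B(O)OC2)Nc1ccccc1` carries an unsubstituted phenyl on the amide. For the measured compounds named here, in a functional assay on MDA-MB-231 cells (Homo sapiens) for antiproliferative activity, read by MTT assay, with a stated time of 72 h (a higher number here means a weaker inhibitor, a lower number a stronger inhibitor), compound 1 gives 230 nM, the lowest of the three numbers so far. Compound 2 `CC(C)(C)OC(=O)Nc1ccc(NC(=O)CCc2cccc3c2B(O)OC3)cc1` has (tert-butoxycarbonyl)amino in place of hydrogen on an aromatic carbon; in this assay compound 2 gives 29000 nM, and a 130-fold higher number from compound 1 to compound 2 (2.10 log units; beyond the scatter). Compound 3 `O=C(CCc1cccc2c1B(O)OC2)Nc1ccc([N+](=O)[O-])cc1` has nitro in place of hydrogen on an aromatic carbon; in this assay compound 3 gives 36000 nM, and a 160-fold higher number from compound 1 to compound 3 (2.19 log units; beyond the scatter). Between the two substituted compounds a 1.2-fold higher number from compound 2 to compound 3 (0.09 log units; within the scatter). Compound 4 `O=C(CCc1cccc2c1B(O)OC2)Nc1cccc(I)c1` is not yet measured and differs from compound 1 in one place: iodo in place of hydrogen on an aromatic carbon. The two measured additions to the phenyl ring of compound 1 both brought large losses, but each added a different group at a different place, so they bear on this change only loosely. Compound 4 is expected to be a weaker inhibitor than compound 1, with an 8.7-fold higher number from compound 1 to compound 4 (0.94 log units; beyond the scatter) estimated as a smaller step than those two. In this assay compound 4 is estimated to give 2000 nM, between 300 nM and 15000 nM.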

Compound 4, half-maximal inhibitory concentration: 5300 nM
Compound 4: the middle estimate sits 2.7-fold (0.42 log units) below what was measured; the range from low to high includes it.
By their numbers in this assay, from the lowest: compound 1; then compound 4; then compounds 2 and 3 (each within the scatter of the next).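

With a 23-fold higher number from compound 1 to compound 4 (1.36 log units; beyond the scatter) in this assay, the result shows that the loss seen on the phenyl ring of compound 1 does not need a group as large as (tert-butoxycarbonyl)amino: a single iodine atom, on an aromatic carbon meta to a large group, is already enough for a large step. All three substituted compounds now have higher numbers than compound 1, none goes against this, and the finding extends to a second place on the ring. No measurement shown here accounts for the loss at this position.

The compounds shown leave open whether a smaller group at this same carbon, such as fluoro or methyl, or an amine there, would keep the number close to that of compound 1. They also leave open how much of the loss belongs to the iodo group and how much to its place, since no single group appears at two places on the ring.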